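From compound 2 to compound 3: adding a methoxy

This account rests on a few compounds, and the source may have more. Where it says the series, first, only, none or still open, it means among the compounds named here.

Of the compounds shown here, two have so far been tested in an ADME assay on BJ cells (Homo sapiens) for cytotoxicity, with a stated time of 72 h (a higher number here means that more compound is needed for the effect, a lower number that less compound is needed), and neither has yielded an exact number. Compound 1 `COc1ccc(-c2nc3ccccc3o2)cc1NC(=O)c1cc([N+](=O)[O-])ccc1Cl` gives > 25000 nM as a limit of the assay and not as a number. Compound 2 `O=C(Nc1cccc(-c2nc3ccccc3s2)c1)c1cc([N+](=O)[O-])ccc1Cl` gives > 27000 nM as a limit too, so it has no exact standing here. For the measured compounds named here, with only limits available, no measured step exists to guide the next one. The change methoxy in place of hydrogen on an aromatic carbon leads from compound 2 to compound 3 `COc1ccc(-c2nc3ccccc3s2)cc1NC(=O)c1cc([N+](=O)[O-])ccc1Cl` and places a methoxy in the position of a hydrogen on an aromatic carbon. No step beyond the usual scatter is expected in this assay and a further limit is the likely result. The expected step that the limit leaves unreadable from compound 2 to compound 3 is an estimate that stays within the scatter. For compound 3 the estimated value is 30000 nM with an expected range from 12000 nM to 60000 nM in all.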

Compound 3, half-maximal effective concentration: > 25000 nM
Compound 3 gave a limit, no number (the forecaster's own chance of this, stated with the estimate: 85%); the middle value is on the limit's open side.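

Compound 1, compound 2 and compound 3 each gave only a limit, not a number, in this assay, so neither new step can be read. The compounds shown leave open whether the methoxy or the 1,3-benzothiazol-2-yl group changes the read-out at all.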